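Limit-bound amines in L1210 inhibition: adding ethyl

The source may hold more compounds than are shown below. What is called first, only, known or untested is meant among the compounds shown, and "the series" means these compounds.

Measured in a functional assay on L1210 cells (Mus musculus) for inhibition, with a stated time of 48 h; a lower number here means a stronger inhibitor, a higher number a weaker inhibitor:
- compound 1 `CNCCCNCCCNC`: > 100000 nM
- compound 2 `CCNCCCNCCCN`: > 100000 nM

Neither entry is a number, and the record for the series reads (the limit of > 100000 nM in this assay, at which 2 of the 2 values shown sit). Among the measured compounds shown here, no measured step exists between the two compounds, so nothing in the data sets the size of a change.

Compound 2 stands at > 100000 nM, which is a limit of the assay. Compound 3 `CCNCCCNCCCNCC` carries ethyl in place of hydrogen on an amine nitrogen.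

An effect in this assay is expected toward stronger inhibition, though only a modest one, and a reading at the same limit would fit equally well. The expected size is an at least 2.0-fold lower number from compound 2 to compound 3 (0.30 log units; that floor lies within the scatter), an estimate measured from a limit and not from a number. For compound 3 the estimated value is 50000 nM, with an expected range of 8000 nM to 150000 nM.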

Compound 3, half-maximal inhibitory concentration: > 100000 nM
Compound 3: a limit, no number; the forecaster's own chance of this, stated with the estimate: 50%; middle value at least 2.0-fold (0.30 log units) away from the limit.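

The step from compound 2 to compound 3, ethyl in place of hydrogen on an amine nitrogen, cannot be read, as both entries are limits and not numbers: the limit of > 100000 nM in this assay, at which 3 of the 3 values shown sit.

The compounds shown leave open whether ethyl on an amine nitrogen has any effect in this assay.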